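Swapping Ethoxy for Chloromethyl at the Carbonyl

The source may report more compounds than this note shows. Statements on the series, on what has been measured and on what is new or still open speak of the compounds shown alone.

Compound 1 `Cc1nc(C)c(CN2CCN(C(=O)CCc3ccccc3)CC2)nc1C`: 150000 nM
Compound 2 `CCOC(=O)N1CCN(Cc2nc(C)c(C)nc2C)CC1`: 76600 nM

Both compounds share one core and differ only in the group attached to the carbonyl carbon. In a functional assay on ECV-304 cells (Homo sapiens), with stated times of 30 min and 6 h (a lower number here means that less compound is needed, a higher number that more compound is needed for the effect), compound 1 gives 150000 nM, while compound 2 gives 76600 nM. Compound 2 thus holds the lower of the two numbers, but the step of a 2.0-fold lower number from compound 1 to compound 2 (0.29 log units; within the scatter) lies within the scatter, so the two cannot be ranked against each other.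

Compound 3 `Cc1nc(C)c(CN2CCN(C(=O)CCl)CC2)nc1C` is the next compound in this series. Compared with compound 2, the change is chloromethyl in place of ethoxy on a carbonyl carbon. Among the compounds with values here, the only measured step, a 2.0-fold lower number from compound 1 to compound 2 (0.29 log units; within the scatter), also altered the group on this same carbonyl carbon, yet neither of its groups was chloromethyl, so it offers no direct guide to the new group; it shows only that one exchange at this position left the number essentially unchanged. On that thin basis, no step beyond the scatter in this assay is expected, though the uncertainty is wide. Compound 3 is therefore estimated to give 80000 nM, with a range from 20000 nM to 320000 nM. This estimate corresponds to an expected step of a 1.0-fold higher number from compound 2 to compound 3 (0.02 log units; within the scatter).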

Compound 3, half-maximal effective concentration: 148000 nM
Beside the measured number, compound 3's estimate is 1.9-fold (0.27 log units) below it; the range from low to high includes it.
By their numbers in this assay, from the lowest: compounds 2, 3 and 1 (each within the scatter of the next).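

Placing chloromethyl on the carbonyl carbon gives the step of a 1.9-fold higher number from compound 2 to compound 3 (0.29 log units; within the scatter) in this assay, so compound 2 and compound 3 cannot be ranked, even though ethoxy counts 1 hydrogen-bond acceptor and chloromethyl counts 0. The step of a 1.0-fold lower number from compound 1 to compound 3 (0.01 log units; within the scatter) is also within the scatter, so compound 3, with chloro and no ring at the end of its short chain, cannot be told apart from compound 1, which carries benzyl in that place and so holds a ring. Across these three compounds, then, ethoxy, chloromethyl and the longer phenethyl group have all been exchanged on this carbonyl carbon without any step beyond the scatter, which is more than the single earlier step could show.

From the compounds shown here alone, whether an amine or a carboxylic acid on this carbonyl carbon would give a step beyond the scatter remains open. No measurement is at hand that could explain why these three groups cannot be separated.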